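The source may report more compounds than this note shows. Statements on the series, on what has been measured and on what is new or still open speak of the compounds shown alone.

In a functional assay on SW1573 cells (Homo sapiens) for antiproliferative activity, read by sulforhodamine B assay, with a stated time of 48 h (a higher number here means a weaker inhibitor of growth, a lower number a stronger inhibitor of growth), the measured compounds are:
- compound 1 `CCCCCCC[C@H]1OC(=O)C[C@H]1OC1CCCCC1` gives 18000 nM
- compound 2 `CCCCCCC[C@H]1OC(=O)C[C@H]1OC1C=CCCC1` gives 23000 nM
- compound 3 `CCCCCCC[C@H]1OC(=O)C[C@H]1OCc1ccccc1` gives 52000 nM

Compound 3 has the highest number of the three, which makes it the weakest growth inhibitor here. It lies above its neighbours by a 2.3-fold higher number from compound 2 to compound 3 (0.35 log units; beyond the scatter) and by a 2.9-fold higher number from compound 1 to compound 3 (0.46 log units; beyond the scatter) in modest steps.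

In compound 4 `C=CCC(C)O[C@@H]1CC(=O)O[C@@H]1CCCCCCC` 1-methylbut-3-en-1-yl replaces benzyl on an oxygen on a saturated carbon, the difference being 1-methylbut-3-en-1-yl in place of benzyl on an oxygen on a saturated carbon and the core staying the same.

The closest evidence is those two modest steps, where benzyl replaced a group without an aromatic ring. The step of a 1.3-fold higher number from compound 1 to compound 2 (0.11 log units; within the scatter) shows that adding a double bond to the cyclohexyl ring changed nothing measurable. Among the measured compounds shown here, no measured compound carries an open chain on this oxygen, so the reasoning stretches beyond the data.

A similar modest step back toward lower numbers is expected in this assay, estimated as a 2.2-fold lower number from compound 3 to compound 4 (0.34 log units; beyond the scatter) overall. Compound 4 is expected near 24000 nM, with an estimated range of 11000 nM to 55000 nM.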

Compound 4, concentration for 50% growth inhibition: 33000 nM
Beside the measured number, compound 4's estimate is 1.4-fold (0.14 log units) below it; low and high end bracket the measured number.
By their numbers in this assay, from the lowest: compounds 1, 2, 4 and 3 (each within the scatter of the next, the first and the last beyond it).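

In this assay, among the compounds shown here, 1-methylbut-3-en-1-yl is the first group on this oxygen with no ring, and the step is a 1.6-fold lower number from compound 3 to compound 4 (0.20 log units; within the scatter) when it replaces benzyl, a 1.4-fold higher number from compound 2 to compound 4 (0.16 log units; within the scatter) when it replaces cyclohex-2-en-1-yl and a 1.8-fold higher number from compound 1 to compound 4 (0.26 log units; within the scatter) when it replaces cyclohexyl. A ring on this oxygen is therefore not required for growth inhibition at this level, and the open chain cannot be told apart from any of the three ring-bearing groups, so the only gap beyond the scatter remains the one separating benzyl from the two cyclohexane-type rings. Nothing measured here accounts for these results. Going by these compounds, it remains open whether an amine or a carboxylic acid on this open chain, or a longer chain in its place, would move the number beyond the scatter. The compounds shown also leave open whether any group at this position can give a much stronger inhibitor of growth than compound 1 at 18000 nM in this assay.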